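The source may report more compounds than this note shows. Statements on the series, on what has been measured and on what is new or still open speak of the compounds shown alone.

In a functional assay on Jurkat cells (Homo sapiens) for cytotoxicity, with a stated time of 72 h; on this read-out higher numbers stand for an effect only at larger amounts of compound and lower numbers for an effect already at smaller amounts:

- Compound 1 `C=C[C@@](C)(/C=C/c1ccc(O)c(C=O)c1)CCC=C(C)C`: > 49000 nM (a limit)
- Compound 2 `C=C[C@@](C)(/C=C/c1ccc(O)c(/C=C/C(=O)OCC)c1)CCC=C(C)C`: > 49000 nM (a limit)
- Compound 3 `CCOC(=O)/C=C/c1cc(/C=C/[C@](C)(/C=C/c2ccc(OC)cc2)CCC=C(C)C)ccc1O`: > 49000 nM (a limit)

Compound 3 therefore has no number, only (the limit of > 49000 nM in this assay, at which 3 of the 3 values shown sit). Compound 4 `COc1ccc(/C=C/[C@@](C)(/C=C/c2ccc(O)c(/C=C/C(=O)c3ccccc3)c2)CCC=C(C)C)cc1` differs from it as follows: phenyl in place of ethoxy on a carbonyl carbon. This is phenyl in place of ethoxy on a carbonyl carbon, turning 2-(ethoxycarbonyl)ethenyl into 2-benzoylethenyl. The measured step that concerns the same group is a step that the two limits leave unreadable from compound 1 to compound 2. The other is a step that the two limits leave unreadable from compound 2 to compound 3. Neither offers a size, so no direction can be drawn from them, and a further limit is quite possible in this assay. The expected change is small: an at least 1.2-fold lower number from compound 3 to compound 4 (0.08 log units; that floor lies within the scatter). Compound 4 is estimated at 40000 nM, with an expected range of 12000 nM to 70000 nM.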

Compound 4, half-maximal effective concentration: > 49000 nM
Compound 4 gave a limit, no number (the forecaster's own chance of this, stated with the estimate: 65%); at least 1.2-fold (0.08 log units) between middle value and limit.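

Compound 3 and compound 4 both give only a limit, and the step between them cannot be read: the limit of > 49000 nM in this assay, at which 4 of the 4 values shown sit. The compounds shown leave open what number any of them would reach in this assay.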